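The source may report more compounds than this note shows. Statements on the series, on what has been measured and on what is new or still open speak of the compounds shown alone.

Measured compounds in a functional assay on HepG2 cells (Homo sapiens) for antiproliferative activity, read by MTT assay, with a stated time of 48 h; a lower number here means a stronger inhibitor, a higher number a weaker inhibitor:
compound 1, `Cc1ccc(NC(=O)Nc2cccc(CNc3nccnc3Cl)c2)cc1C`, gives 10700 nM.
compound 2, `Cc1ccc(NC(=O)Nc2cccc(CNc3nccnc3Cl)c2)cc1`, gives 11500 nM.
compound 3, `O=C(Nc1cccc(CNc2nccnc2Cl)c1)Nc1cccc2ccccc12`, gives only > 40000 nM, which is a limit of this assay and not a number.

Compound 2 holds the highest of the two numbers recorded in this assay; its nearest neighbour is compound 1, and the step of a 1.1-fold higher number from compound 1 to compound 2 (0.03 log units; within the scatter) lies within the scatter, so the two are not separable. Compound 3 sits at the limit of > 40000 nM in this assay, at which 1 of the 3 values shown sits.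

Compound 4, `O=C(Nc1cccc(CNc2nccnc2Cl)c1)Nc1ccccc1Cl`, is still to be measured in this assay. It differs from compound 2 by 2-chlorophenyl in place of 4-methylphenyl on an amide-type nitrogen. Among the compounds with values here, the only measured step that touches this part of the series is a 1.1-fold higher number from compound 1 to compound 2 (0.03 log units; within the scatter): a methyl removed from the aromatic ring on this nitrogen changed nothing beyond the scatter. Within the data shown here, compound 3, which also alters the group on this nitrogen, registers only a limit, so changes here can push the number out of range, but no measured pair shows the effect of a chlorine.

The expected outcome for compound 4 is a small shift, a 1.2-fold higher number from compound 2 to compound 4 (0.09 log units; within the scatter), toward a weaker inhibitor, within or just beyond the scatter. Compound 4 is therefore estimated at 14000 nM, with a range from 5000 nM to 40000 nM.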

Compound 4, half-maximal inhibitory concentration: 8560 nM
Compound 4: the middle estimate sits 1.6-fold (0.21 log units) above what was measured; the measured number falls inside the stated range.
By their numbers in this assay, from the lowest: compounds 4, 1 and 2 (each within the scatter of the next). At a limit, above all of these: compound 3.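

In this assay, replacing the group on the amide-type nitrogen with 2-chlorophenyl moves the number only within the scatter: a 1.3-fold lower number from compound 2 to compound 4 (0.13 log units; within the scatter), and a 1.3-fold lower number from compound 1 to compound 4 (0.10 log units; within the scatter). Compounds 1, 2 and 4 therefore cannot be separated here, so the tolerance at this position now extends beyond the loss of a methyl to an exchange of 4-methylphenyl or 3,4-dimethylphenyl for a chlorine-bearing phenyl group. Compound 3, with another group on this nitrogen, remains the only compound out of range, and its value is a limit of the assay and not a number: the limit of > 40000 nM in this assay, at which 1 of the 4 values shown sits.

As far as these compounds go, it remains open whether this flat response holds for other groups on the phenyl ring, such as methoxy, nitrile, trifluoromethyl, an amine or a carboxylic acid, and which feature of the group in compound 3 separates it from the other three compounds. All the compounds shown keep the shared core unchanged, so the effect of replacing its chlorine with an amine or a methoxy group also remains unknown.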